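Rearranging the amine chain: compound 3 to compound 4

The source may report more compounds than this note shows. Statements on the series, on what has been measured and on what is new or still open speak of the compounds shown alone.

Three compounds sharing one core were tested in a functional assay on cells for agonist activity at C-X-C chemokine receptor type 4 (Homo sapiens), read by fluorescence and calcium flux, with a stated time of 90 s; on this read-out higher numbers stand for an effect only at larger amounts of compound and lower numbers for an effect already at smaller amounts. Compound 1 `c1ccc2c(c1)CN[C@@H](CN(CCCCNC1CCOCC1)[C@H]1CCCc3cccnc31)C2` carries a 3-((oxan-4-yl)amino)propyl group on the amine nitrogen. Compound 2 `NCc1ccccc1CN(C[C@H]1Cc2ccccc2CN1)[C@H]1CCCc2cccnc21` has 2-(aminomethyl)phenyl in its place, and compound 3 `CC(C)(CN)CCN(C[C@H]1Cc2ccccc2CN1)[C@H]1CCCc2cccnc21` has 2-(aminomethyl)-2-methylpropyl. In this assay compound 1 reached only the assay limit, > 30000 nM. Compound 2 likewise gave only a limit, > 30000 nM. Compound 3 also stopped at a limit, > 30000 nM. So compound 3 stands nowhere distinct on the numbers shown: all three values sit at the same limit (the limit of > 30000 nM in this assay, at which 3 of the 3 values shown sit), and the steps a step that the two limits leave unreadable from compound 1 to compound 2, a step that the two limits leave unreadable from compound 1 to compound 3 and a step that the two limits leave unreadable from compound 2 to compound 3 cannot be read in size or direction.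

Compound 4 `CC(C)(N)CCCN(C[C@H]1Cc2ccccc2CN1)[C@H]1CCCc2cccnc21` differs from compound 3 by 2-amino-2-methylpropyl in place of 1-(aminomethyl)-1-methylethyl on a saturated chain carbon, two bonds along the chain from an amine nitrogen. The two contain the same atoms, joined differently. For the measured compounds named here, none of the measured steps gives a readable size, so no direction can be inferred for this change; the only guide is that every measured value rests at the limit. The step from compound 3 to compound 4 is therefore expected to be a step that the limit leaves unreadable from compound 3 to compound 4, that is, no shift beyond the scatter. Compound 4 is estimated to give about 40000 nM in this assay, within a range from 10000 nM to 150000 nM, most probably reported again only as a limit.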

Compound 4, half-maximal effective concentration: > 30000 nM
Compound 4 was reported as a limit; the forecaster's own chance of this, stated with the estimate: 80%; the middle value lies beyond the limit too.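

In this assay compound 4 gives > 30000 nM, which is a limit of the assay, so its steps from compound 1, compound 2 and compound 3 cannot be read in size or direction. The four compounds rest at one value: the limit of > 30000 nM in this assay, at which 4 of the 4 values shown sit.

The compounds shown leave open whether any of these amine chains gives a measurable effect, and how compounds 1 to 4 rank against one another.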